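Series notes: chloro in place of methoxy, compound 3

The compounds below may be only part of what the source reports. "The series", "measured", "known", "first", "only" and "open" are said of these compounds alone.

In a toxicity assay on MDCK cells (Canis lupus familiaris) for cytotoxicity, read by MTT assay, with a stated time of 48 h (a higher number here means that more compound is tolerated, a lower number that less compound is tolerated), compound 1 `Cc1ccccc1OCCn1/c(=N/C(=O)c2cccs2)[nH]c2ccccc21` gives 159000 nM. Compound 2 `COc1ccc(OCCn2/c(=N/C(=O)c3cccs3)[nH]c3ccccc32)cc1` reaches only a limit in this assay, > 2540000 nM, so its position is known only as that limit (the limit of > 2540000 nM in this assay, at which 1 of the 2 values shown sits). Going by the values given here, the single measured step, an at least 15-fold higher number from compound 1 to compound 2 (1.20 log units; beyond the scatter), concerns a different exchange on the same oxygen and gives only indirect guidance. Compound 3 `O=C(/N=c1\[nH]c2ccccc2n1CCOc1ccc(Cl)cc1)c1cccs1` differs from compound 2 by chloro in place of methoxy on an aromatic carbon. Among the compounds with values here, with no direct precedent, compound 3 is expected to stay close to compound 2, a step of an at least 1.6-fold lower number from compound 2 to compound 3 (0.22 log units; that floor lies within the scatter), and a further limit is quite possible. The estimate for compound 3 is 1500000 nM, within 400000 nM to 5000000 nM.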

Compound 3, half-maximal cytotoxic concentration: 2240000 nM
Compound 3: the middle estimate sits 1.5-fold (0.17 log units) below what was measured; the measured number falls inside the stated range.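

In this assay chloro in place of methoxy, para to a large group, gives an at least 1.1-fold lower number from compound 2 to compound 3 (0.05 log units; that floor lies within the scatter) and so shows no exchange effect beyond the scatter, though this is a floor only. Compound 2 stands as a limit, so the true size of the exchange stays unfixed: the limit of > 2540000 nM in this assay, at which 1 of the 3 values shown sits. The step of a 14-fold higher number from compound 1 to compound 3 (1.15 log units; beyond the scatter) adds a measured number showing that 4-chlorophenyl, not only 4-methoxyphenyl, stands clear of 2-methylphenyl. Open remains how an amine or a carboxylic acid on this aromatic carbon would read in this assay.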